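The source may report more compounds than this note shows. Statements on the series, on what has been measured and on what is new or still open speak of the compounds shown alone.

Of the compounds shown here, three built on one shared core have been tested in an assay on isolated protein for inhibition of leukotriene B4 receptor 1 (Homo sapiens), tested at 10 uM; on this read-out higher numbers stand for more inhibition at the one concentration tested (going by the name of the read-out) and lower numbers for less inhibition. Compound 1 `C=CCc1cc(C(C)=O)c(O)cc1OCCCCCC#N` gives 81%, compound 2 `CCc1cc(C(C)=O)c(O)cc1OCCCCCC(C)(C)C#N` gives 85%, and compound 3 `CCCc1cc(C(C)=O)c(O)cc1OCCCCC(=O)O` gives 11%. Compound 2 holds the highest of the three numbers, but its nearest neighbour, compound 1, sits within the usual scatter of it, so the two cannot be ranked against each other; compound 3, by contrast, lies far below compound 2, well beyond the scatter.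

Compound 4 `CCc1cc(C(C)=O)c(O)cc1OCCCCCn1cncn1` has not yet been measured. It differs from compound 2 in one place: 1H-1,2,4-triazol-1-yl in place of 1-cyano-1-methylethyl on a saturated chain carbon, five bonds along the chain from an oxygen on an aromatic ring. Going by the values given here, no measured pair of compounds shows this particular change, so nothing measured tells its size directly. The nitrile that both compound 1 and compound 2 carry at the end of the chain is lost, while the carboxylic acid that accompanies the low value of compound 3 is not introduced either.

Compound 4 is expected to give 55% in this assay, with a range from 20% to 85%. The expected step, a number 30 percentage points lower from compound 2 to compound 4 (beyond the scatter), is a moderate decrease, somewhat beyond the scatter, because compound 2 gives 85% and a loss of the nitrile leaves this unsupported.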

Compound 4, a percentage reported as inhibition, at one concentration (the size of the read-out at that concentration, not a potency): 82%
Compound 4: the middle estimate sits 27 percentage points below what was measured; the measured number falls inside the stated range.
By their numbers in this assay, from the lowest: compound 3; then compounds 1, 4 and 2 (each within the scatter of the next).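

Replacing 1-cyano-1-methylethyl with 1H-1,2,4-triazol-1-yl on this saturated chain carbon gives, in this assay, a number 3 percentage points lower from compound 2 to compound 4 (within the scatter). A high number at this place therefore does not depend on a nitrile, since the group that enters has no triple bond and brings a five-membered aromatic ring with 3 hetero atoms. Nothing available explains why these two different groups give such similar numbers.

Going by these compounds, it remains open how an amine or an amide at this same place would read, with the rest of compound 4 kept unchanged. On these data alone, a shorter or longer chain carrying 1H-1,2,4-triazol-1-yl is also open, as is whether compounds that read alike at one concentration would also match in potency.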